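The compounds below may be only part of what the source reports. "The series", "measured", "known", "first", "only" and "open" are said of these compounds alone.

Measured compounds:
Compound 1, `COc1ccc(-c2nc(C)c(C(=O)CSc3nc(N)c(C#N)c(-c4ccc(Cl)cc4)n3)s2)cc1`: 1.1%
Compound 2, `Cc1nc(-c2ccccc2)sc1C(=O)CSc1nc(N)c(C#N)c(-c2ccc(Cl)cc2)n1`: -23%

Both were tested in an assay on membranes from CHO cells for displacement of a labelled ligand from adenosine receptor A1 (Homo sapiens), read by scintillation counting, with a stated time of 60 min, tested at 1 uM; on this read-out higher numbers stand for more inhibition at the one concentration tested (going by the name of the read-out) and lower numbers for less inhibition. Compound 2 stands lowest of the two numbers; its nearest neighbour is compound 1, and the step of a number 24.1 percentage points lower from compound 1 to compound 2 (beyond the scatter) lies beyond the scatter. Compound 3, `Cc1nc(-c2ccc(Cl)cc2)sc1C(=O)CSc1nc(N)c(C#N)c(-c2ccc(Cl)cc2)n1`, differs from compound 2 by chloro in place of hydrogen on an aromatic carbon. Among the compounds with values here, the only measured step that bears on this place is a number 24.1 percentage points lower from compound 1 to compound 2 (beyond the scatter), showing that a group here can shift the read-out modestly. Compound 3 is therefore expected to shift by a number 18 percentage points higher from compound 2 to compound 3 (beyond the scatter), most likely upward, with its value in this assay estimated at -5%, within -35% to 25%.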

Compound 3, a percentage reported as inhibition, at one concentration (the size of the read-out at that concentration, not a potency): -3.7%
Compound 3: middle estimate off by 1.3 percentage points, on the low side, and the stated range covers the measured number.
By their numbers in this assay, from the lowest: compound 2; then compounds 3 and 1 (each within the scatter of the next).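

Within the data shown here, the change from phenyl to 4-chlorophenyl gives a number 19.3 percentage points higher from compound 2 to compound 3 (beyond the scatter) and so shows that methoxy is not the only group at this ring carbon that separates a compound from compound 2. Chloro and methoxy cannot be told apart here, with a number 4.8 percentage points lower from compound 1 to compound 3 (within the scatter) as the step between them. No measurement on hand gives a cause for these shifts.

As far as these compounds go, whether an amine or a carboxylic acid on the same ring carbon would move the read-out further remains open. A reading at one concentration also gives no potency for any of the three compounds.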